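The source may report more compounds than this note shows. Statements on the series, on what has been measured and on what is new or still open speak of the compounds shown alone.

Three compounds of this set share a related scaffold and have been measured in a functional assay on A549 cells (Homo sapiens) for inhibition, read by MTT assay, with a stated time of 72 h; a lower number here means a stronger inhibitor of growth, a higher number a weaker inhibitor of growth. Compound 3 `Clc1ccc(Sc2c(-c3ccc(Cl)cc3)[nH]c3ccccc23)cc1` gives 27000 nM. Compound 1 `Clc1ccc(Sc2c(-c3ccc(Cl)cc3)[nH]c3ccc(Cl)cc23)cc1` carries one more substituent than compound 3; the difference is chloro in place of hydrogen on an aromatic carbon, and in this assay compound 1 gives 27000 nM. The resulting step is no change at the digits printed from compound 3 to compound 1 (within the scatter). Compound 2 `OC1CCCN(C(=S)Sc2c(-c3ccc(Br)cc3)[nH]c3ccccc23)C1` differs from compound 3 in more than a single place, and the difference between the two cores is not broken down here; in this assay compound 2 gives 24000 nM, a value that sits within the scatter of both compound 1 and compound 3, so no order among the three can be read from these numbers.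

Compound 4 `OC1CCCN(C(=S)Sc2c(-c3ccc(Br)cc3)[nH]c3ccc(Cl)cc23)C1` has not yet been measured. It stands to compound 2 as compound 1 stands to compound 3: the change is chloro in place of hydrogen on an aromatic carbon, and the descriptions of where the new group sits agree word for word, so it is the same change seen before. Among the measured compounds shown here, that earlier instance, no change at the digits printed from compound 3 to compound 1 (within the scatter), gives the only guide available, and it points to no movement. The step from compound 2 to compound 4 is therefore expected to be no change at the digits printed from compound 2 to compound 4 (within the scatter), resting on no change at the digits printed from compound 3 to compound 1 (within the scatter). On that basis compound 4 is estimated at 24000 nM in this assay, with a likely range from 10000 nM to 55000 nM, an expectation that the coming measurement will test.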

Compound 4, concentration for 50% growth inhibition: 29000 nM
For compound 4 the middle estimate is 1.2-fold (0.08 log units) below the measured one, and the stated range covers the measured number.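

In this assay, chloro in place of hydrogen on an aromatic carbon gives a 1.2-fold higher number from compound 2 to compound 4 (0.08 log units; within the scatter), and the two instances of this change agree: the same change on two cores in this assay, no change at the digits printed (within the scatter) from compound 3 to compound 1 and a 1.2-fold higher number (0.08 log units; within the scatter) from compound 2 to compound 4, 1.2-fold (0.08 log units) apart, within the scatter of two such steps This shows that, on the core of compound 3 and on the core of compound 2, which differ in more than one place, the change leaves the number within the scatter, so the flat result seen on the first core carried over to the second. Among the compounds shown here, it does not show that the change is silent across the series, as the evidence is only two matched pairs whose numbers all lie close together, and it says nothing about why the chloro makes no measurable difference or about any core whose number lies far from these.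

The compounds shown leave open whether a different group on the same aromatic carbon, such as methoxy, an amine or a carboxylic acid, would move the number in this assay. They also leave open whether the chloro would stay as flat on a core with a much lower number, where a step in either direction might be easier to see.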